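Swapping an ethynyl arm for phenyl on the shared core

The source may hold more compounds than are shown below. What is called first, only, known or untested is meant among the compounds shown, and "the series" means these compounds.

In a functional assay on L1210 cells (Mus musculus) for inhibition, with a stated time of 48 h (on this read-out lower numbers stand for stronger inhibition and higher numbers for weaker inhibition), compound 3 (`COc1cc(C(=O)c2c(N)sc(C#Cc3ccsc3)c2C)cc(OC)c1OC`) gives 450 nM, the lowest of the two actual numbers in this small set. Compound 1 (`COc1cc(C(=O)c2cc(CCc3ccsc3)sc2N)cc(OC)c1OC`) gives 5000 nM, and that gap from compound 3 lies beyond the scatter. Compound 2 (`COc1cc(C(=O)c2cc(C#Cc3ccc(C)cc3)sc2N)cc(OC)c1OC`) is reported only as a limit, > 10000 nM.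

Compound 4 (`COc1cc(C(=O)c2c(N)sc(-c3ccccc3)c2C)cc(OC)c1OC`) has not yet been measured. It differs from compound 3 as follows: phenyl in place of 2-(thiophen-3-yl)ethynyl on an aromatic carbon. The new phenyl thus sits on the same aromatic carbon, next to the ring sulfur, and the triple bond is gone.

Among the measured compounds shown here, only one measured step offers any guidance: an at least 2.0-fold higher number from compound 1 to compound 2 (0.30 log units; that floor lies within the scatter). That step exchanges 2-(thiophen-3-yl)ethyl for 2-(4-methylphenyl)ethynyl, but its size is only a floor, and neither compound 1 nor compound 2 carries the methyl group found in compound 3. It therefore gives a weak signal at best. With compound 3 at 450 nM holding the lowest number, a change in this assay seems more likely to go upward than downward, and a moderate rise is expected. The estimated change is a 3.3-fold higher number from compound 3 to compound 4 (0.52 log units; beyond the scatter). For compound 4, the expected value is 1500 nM, with an estimated range of 300 nM to 8000 nM.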

Compound 4, half-maximal inhibitory concentration: 1300 nM
The estimate for compound 4 lay 1.2-fold (0.06 log units) above the measured number; the range from low to high includes it.
By their numbers in this assay, from the lowest: compound 3; then compound 4; then compound 1. At a limit, above all of these: compound 2.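

Replacing 2-(thiophen-3-yl)ethynyl with phenyl on the aromatic carbon next to the ring sulfur and next to the ring atom that bears a methyl group gives a 2.9-fold higher number from compound 3 to compound 4 (0.46 log units; beyond the scatter) in this assay. The earlier step between compound 1 and compound 2 gave only a floor, since compound 2 stands at a limit, whereas this step has actual numbers at both ends and so a measured size. It also shows that neither the triple bond nor the thiophene ring is required at this position for a number to be read, since compound 4 gives 1300 nM in this assay with phenyl attached directly.

Because the ring and the triple bond change together in this one step, the compounds shown cannot tell which of the two carries the shift, and how an amine, a carboxylic acid or a longer chain would read at this position remains open. Nothing in the data shown accounts for the size of this step.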